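Swapping 2-fluorophenyl for 4-methylphenyl on an aromatic nitrogen

A few compounds are considered here, and "the series" means these few. Any claim that something is new, unique, unknown or untested is made for them only; others in the source may bear on it.

Compound 1 `COc1cc(C(=O)c2cn(-c3ccccc3)cc2-c2cccc(C)c2)cc(OC)c1OC`: 450 nM
Compound 2 `COc1cc(C(=O)c2cn(-c3ccccc3)cc2-c2cccc(F)c2)cc(OC)c1OC`: 57 nM
Compound 3 `COc1cc(C(=O)c2cn(-c3ccccc3F)cc2-c2ccccc2)cc(OC)c1OC`: 85 nM

In a functional assay on MCF7 cells (Homo sapiens) for inhibition, read by trypan blue exclusion, with a stated time of 3 days (on this read-out lower numbers stand for stronger inhibition and higher numbers for weaker inhibition), compound 3 gives 85 nM, which cannot be told apart from compound 2 at 57 nM. Both numbers sit well under that of compound 1 at 450 nM.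

Compound 4 `COc1cc(C(=O)c2cn(-c3ccc(C)cc3)cc2-c2ccccc2)cc(OC)c1OC` keeps the shared core of compound 3 but carries 4-methylphenyl in place of 2-fluorophenyl on an aromatic nitrogen.

Going by the values given here, no measured step covers a change on this nitrogen. The closest evidence is a 7.9-fold lower number from compound 1 to compound 2 (0.90 log units; beyond the scatter), where fluoro replaces methyl on an aromatic carbon elsewhere in the molecule. The step to compound 4 runs the other way, from a fluorine-bearing group to a methyl-bearing one, so a higher number, meaning weaker inhibition, is expected in this assay. That single step comes from a different place, so only part of its size is expected to carry over, and the uncertainty is wide.

The expected change is a 2.2-fold higher number from compound 3 to compound 4 (0.35 log units; beyond the scatter).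

For compound 4 the estimate is 190 nM, with an expected range from 60 nM to 600 nM.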

Compound 4, half-maximal inhibitory concentration: 30 nM
For compound 4 the middle estimate is 6.3-fold (0.80 log units) above the measured one; the measured number lies below the stated range.
By their numbers in this assay, from the lowest: compounds 4, 2 and 3 (each within the scatter of the next, the first and the last beyond it); then compound 1.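

In this assay the nitrogen position accepts this change well, with a 2.8-fold lower number from compound 3 to compound 4 (0.45 log units; beyond the scatter) as 4-methylphenyl enters and 2-fluorophenyl leaves. Going by these compounds alone, the only earlier step, a 7.9-fold lower number from compound 1 to compound 2 (0.90 log units; beyond the scatter) on swapping methyl for fluoro on an aromatic carbon elsewhere in the molecule, ran the opposite way with respect to these two substituents, so what holds at one place does not carry over to the other. No measurement at hand accounts for the direction or size of the new step.

On these data alone, this single step changes both the substituent and where it sits on the phenyl group, so it remains open whether the lower number comes from gaining the methyl or from losing the fluorine. Also open, as far as these compounds go, is how far this nitrogen position accepts groups of a different kind, such as 4-aminophenyl or 4-carboxyphenyl, or a longer chain in place of the methyl of 4-methylphenyl.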